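Fluoro to hydroxy on the aromatic ring of compound 3

The compounds below may be only part of what the source reports. "The series", "measured", "known", "first", "only" and "open" are said of these compounds alone.

Three compounds share the phenylsulfonamide-capped linker attached to a bicyclic amine core. Compound 1 `COc1ccc2c(c1)CCC(NCCCCCCNS(=O)(=O)c1ccccc1)C2Cc1cccnc1` gives 53 nM in an assay on HEK293 cells for binding affinity to Neuropeptide Y receptor type 5 (Homo sapiens); on this read-out lower numbers stand for stronger inhibition and higher numbers for weaker inhibition. Compound 2 `O=S(=O)(NC[C@H]1CC[C@H](CNC2CCc3cc(F)ccc3C2Cc2cccnc2)CC1)c1ccccc1` gives 27 nM in this assay, and compound 3 `C=CCC1c2ccc(F)cc2CCC1NC[C@H]1CC[C@H](CNS(=O)(=O)c2ccccc2)CC1` gives 21 nM. Going by the values given here, the only single-point step measured, a 1.3-fold lower number from compound 2 to compound 3 (0.11 log units; within the scatter), lies within the scatter. Compound 3 sits at the low end of the three numbers: its gap to compound 2 is within the scatter, while compound 1 stands beyond the scatter with a higher number.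

Compound 4 `C=CCC1c2ccc(O)cc2CCC1NC[C@H]1CC[C@H](CNS(=O)(=O)c2ccccc2)CC1` differs from compound 3 by hydroxy in place of fluoro on an aromatic carbon. Among the compounds with values here, no measured step touches this position: compound 1 carries a different group on its aromatic ring but also differs from compound 3 in the chain and in the pyridinyl group, so its value cannot be read as a step for the hydroxy alone. Within the data shown here, with no step bearing on the change, no shift beyond the scatter is expected in this assay, and a 1.4-fold higher number from compound 3 to compound 4 (0.15 log units; within the scatter) is the estimated step. Compound 4 is expected at 30 nM, with a range from 10 nM to 90 nM.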

Compound 4, half-maximal inhibitory concentration: 5 nM
Beside the measured number, compound 4's estimate is 6.0-fold (0.78 log units) above it; the measured number lies below the stated range.
By their numbers in this assay, from the lowest: compound 4; then compounds 3, 2 and 1 (each within the scatter of the next, the first and the last beyond it).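

In this assay, going by these compounds alone, the aromatic carbon carrying fluoro in compound 3 proves sensitive to substitution: hydroxy in place of fluoro gives a 4.2-fold lower number from compound 3 to compound 4 (0.62 log units; beyond the scatter), beyond the scatter, whereas the only earlier single-point step, a 1.3-fold lower number from compound 2 to compound 3 (0.11 log units; within the scatter), stays within it. The change is small by count, one heavy atom for one heavy atom, with the entering hydroxy adding a hydrogen-bond donor and a hydrogen-bond acceptor that fluoro lacks. No evidence is available that bears on the reason for this shift.

As far as these compounds go, it remains open whether the shift is specific to hydroxy or would also appear with an amine or a carboxamide on the same aromatic carbon. Also open, from the compounds shown here alone, is whether hydroxy in place of fluoro gives a similar step on compound 2, which carries pyridin-3-yl in place of vinyl.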